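This account rests on a few compounds, and the source may have more. Where it says the series, first, only, none or still open, it means among the compounds named here.

In a functional assay on A549 cells (Homo sapiens) for inhibition, read by MTT assay, with a stated time of 72 h (a higher number here means a weaker inhibitor, a lower number a stronger inhibitor), three compounds have been measured so far. Compound 1 (`COC(=O)c1ccc(-n2cc(CCCOC(=O)c3ccc(C)cc3)nn2)cc1`) gives > 100000 nM, which is a limit of the assay and not a number. Compound 2 (`COC(=O)c1ccc(-n2cc(CCCNc3ccc(C)cc3)nn2)cc1`) also gives a limit, > 100000 nM. Among the compounds with values here, compound 3 (`Cc1ccc(NC(=O)CCCn2cc(-c3ccc(C(F)(F)F)cc3)nn2)cc1`) gives 25000 nM, the only actual number among the three. It therefore stands alone on the scale, and the size of any gap between it and the other two cannot be stated.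

Compound 4 (`O=C(CCCn1cc(-c2ccc(C(F)(F)F)cc2)nn1)Nc1ccc(-c2ccccc2)cc1`) keeps the structure of compound 3 except at one place: phenyl in place of methyl on an aromatic carbon, para to a large group (phenyl in place of methyl on an aromatic carbon). Within the data shown here, no measured pair shows a change at this position, so there is no direct precedent for the size or direction of the step. Compound 3, at 25000 nM, is the only anchor for an expectation in this assay. With so little to go on, no shift beyond the usual scatter is expected, with only a slight lean towards a lower number. The estimated change is a 1.4-fold lower number from compound 3 to compound 4 (0.14 log units; within the scatter). For compound 4 the expected value is 18000 nM, with an estimated range from 6000 nM to 60000 nM.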

Compound 4, half-maximal inhibitory concentration: 19100 nM
Compound 4: the middle estimate sits 1.1-fold (0.03 log units) below what was measured; the range from low to high includes it.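

Within the data shown here, replacing methyl with phenyl on an aromatic carbon, para to a large group, gives a 1.3-fold lower number from compound 3 to compound 4 (0.12 log units; within the scatter) in this assay, the first step that can be read. The position therefore accepts a change from 1 heavy atom to 6 heavy atoms, including one six-membered aromatic ring of carbon only, without a shift beyond the usual scatter, and neither methyl nor phenyl can be ranked above the other here. Compound 1 and compound 2 could not have shown this, as each remains a limit of the assay and not a number: the limit of > 100000 nM in this assay, at which 2 of the 4 values shown sit.

The compounds shown leave open whether a different kind of group at this position, such as an amine or a carboxylic acid, would produce a step beyond the scatter, since the one change seen here adds only carbon atoms and no hydrogen-bond donors or acceptors. They also leave open what a longer chain on the carbonyl side of the shared core, or a group other than trifluoromethyl on the far aromatic ring, would do to the number in this assay.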